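Working notes: cytotoxicity of two measured analogues and one untested

A few compounds are considered here, and "the series" means these few. Any claim that something is new, unique, unknown or untested is made for them only; others in the source may bear on it.

Measured so far:
compound 1 `COc1ccc2nc(Cl)c(/C=C3\SC(=S)NC3=O)cc2c1` — > 100 ug/mL
compound 2 `Cc1cccc2cc(/C=C3\SC(=S)N(CC(=O)O)C3=O)c(Cl)nc12` — > 100 ug/mL

In a toxicity assay on A549 cells (Homo sapiens) for cytotoxicity, read by MTT assay, with a stated time of 48 h (on this read-out lower numbers stand for stronger inhibition of growth and higher numbers for weaker inhibition of growth), compound 1 gives > 100 ug/mL, which is a limit of the assay and not a number. Compound 2 gives > 100 ug/mL in this assay, likewise a limit. Compound 2 therefore stands at the limit of > 100 ug/mL in this assay, at which 2 of the 2 values shown sit. Compound 3 `Cc1cccc2cc(/C=C3\SC(=S)NC3=O)c(Cl)nc12` awaits measurement in this assay and differs from compound 2 by hydrogen in place of carboxymethyl on an amide-type nitrogen in a ring. For the measured compounds named here, no step between measured compounds is available, so no measured pair tells the size or direction of this change. Compound 3 is expected to stay at the limit, the estimated step that the limit leaves unreadable from compound 2 to compound 3 being none beyond the scatter. Compound 3 is estimated at 150 ug/mL, with a range from 60 ug/mL to 400 ug/mL.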

Compound 3, concentration for 50% growth inhibition: > 100 ug/mL
Compound 3 was reported as a limit; the forecaster's own chance of this, stated with the estimate: 75%; the middle value is on the limit's open side.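

For the compounds shown here, compound 2 and compound 3 are both reported as limits, not numbers, and no step between them can be read. The compounds shown leave open whether any substituent on the amide-type nitrogen in a ring affects growth inhibition.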